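A few compounds are considered here, and "the series" means these few. Any claim that something is new, unique, unknown or untested is made for them only; others in the source may bear on it.

Within the data shown here, compound 2 `NCc1ccccc1COc1nc(N)nc2nc[nH]c12` stands with the highest number of the two so far: in an assay with Methylated-DNA--protein-cysteine methyltransferase (Homo sapiens) as the target, in the presence of a further agent that is not named here (a higher number here means that more compound is needed for the effect, a lower number that less compound is needed), compound 2 gives 45 uM, whereas compound 1 `NCc1ccc(COc2nc(N)nc3nc[nH]c23)cc1` gives 0.053 uM in this assay. Compound 3 `Cc1ccccc1COc1nc(N)nc2nc[nH]c12` is obtained from compound 2 by hydrogen in place of amino on a saturated chain carbon bound to an aromatic carbon. Among the measured compounds shown here, no measured pair shows this change, so only a guess is possible: the aminomethyl-to-methyl swap is expected to give a small step downward, a 2.3-fold lower number from compound 2 to compound 3 (0.35 log units; beyond the scatter), perhaps not beyond the scatter. For compound 3 the estimate in this assay is 20 uM, with a range from 5 uM to 80 uM.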

Compound 3, concentration for half-maximal effect: 90 uM
Estimate against measurement, compound 3: 4.5-fold (0.65 log units) below, and the stated range ends below it.
By their numbers in this assay, from the lowest: compound 1; then compounds 2 and 3 (each within the scatter of the next).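

In this assay hydrogen in place of amino on a saturated chain carbon bound to an aromatic carbon gives a 2.0-fold higher number from compound 2 to compound 3 (0.30 log units; within the scatter). At this place, the amino group therefore makes no readable difference to the number. Nothing available bears on this result.

As far as these compounds go, whether a hydroxyl, a carboxylic acid or a longer amine chain at this place would give a step beyond the scatter remains open. Also open, from the compounds shown here alone, is whether the same aminomethyl to methyl change on compound 1 would leave its number equally unmoved.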